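The compounds below may be only part of what the source reports. "The series", "measured", "known", "first", "only" and "open" are said of these compounds alone.

Of the compounds shown here, three sharing one core have been measured in a physicochemical assay for lipophilicity; a lower number here means a more polar compound, a higher number a more lipophilic compound. Compound 1 `Cc1nc(C)c(C(=O)Oc2ccc(-c3cc(=O)c4c(O)c(O)c(O)cc4o3)cc2)nc1C` gives 3.01, compound 2 `Cc1nc(C)c(C(=O)N[C@@H](C(=O)Oc2ccc(-c3cc(=O)c4c(O)c(O)c(O)cc4o3)cc2)C(C)C)nc1C` gives 1.38, and compound 3 `Cc1nc(C)c(C(=O)N[C@H](CC(C)C)C(=O)Oc2ccc(-c3cc(=O)c4c(O)c(O)c(O)cc4o3)cc2)nc1C` gives 0.91, the lowest of the three and beyond the scatter of both others. The next structure, compound 4 `Cc1nc(C)c(COC(=O)N[C@H](CC(C)C)C(=O)Oc2ccc(-c3cc(=O)c4c(O)c(O)c(O)cc4o3)cc2)nc1C`, differs from compound 3 in one place: (3,5,6-trimethylpyrazin-2-yl)methoxy takes the place of 3,5,6-trimethylpyrazin-2-yl on a carbonyl carbon ((3,5,6-trimethylpyrazin-2-yl)methoxy in place of 3,5,6-trimethylpyrazin-2-yl on a carbonyl carbon).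

Among the measured compounds shown here, only one measured step connects two compounds that differ in a single place: a number 0.47 log units lower from compound 2 to compound 3 (beyond the scatter). This modest step involves a saturated chain carbon, not the carbonyl carbon changed here, so no measurement tests the new change directly. It does show that a small structural edit can move this number beyond the scatter. For the measured compounds named here, the three values also fall as the structures grow, from compound 1 at 3.01 to compound 3 at 0.91, and no measured compound goes against that trend, though three compounds are a thin base. A small downward move is the reasonable expectation, and it may well stay within the scatter. The expected step is a number 0.16 log units lower from compound 3 to compound 4 (within the scatter). For compound 4 the estimated value is 0.75, with an expected range from 0.1 to 1.4.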

Compound 4, partition coefficient: 1.69
Beside the measured number, compound 4's estimate is 0.94 log units below it; the measured number lies above the stated range.
By their numbers in this assay, from the lowest: compound 3; then compound 2; then compound 4; then compound 1.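

In this assay, putting (3,5,6-trimethylpyrazin-2-yl)methoxy in place of 3,5,6-trimethylpyrazin-2-yl, on a carbonyl carbon whose other neighbour is an amide-type nitrogen, gives a number 0.78 log units higher from compound 3 to compound 4 (beyond the scatter), so this place responds to a change of this size and the number goes up. Among the compounds shown here, the one earlier step, a number 0.47 log units lower from compound 2 to compound 3 (beyond the scatter), sits at a different place, a saturated chain carbon, and runs the other way, so the two edits do not push the number in the same direction, and compound 4 goes against the earlier fall of the values as the structures grew. Nothing measured here accounts for the rise at the carbonyl carbon.

The entering group brings its added carbon and its oxygen together, so the compounds shown cannot say which of the two carries the step; an amine in place of that oxygen, or a longer chain leading to the same 3,5,6-trimethylpyrazin-2-yl, would pull those apart. Also open, on these data alone, is whether the same swap moves the number as far when isopropyl, as in compound 2, replaces isobutyl on the chain carbon.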